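The source may hold more compounds than are shown below. What is called first, only, known or untested is meant among the compounds shown, and "the series" means these compounds.

Compound 1, `COc1ccc(NC(=O)c2cccc(/C=C3\CC(=O)N(c4ccccc4)C3=O)c2)c(C)c1`, in an ADME assay on SW480 cells (Homo sapiens) for cytotoxicity, read by MTT assay, with a stated time of 72 h (on this read-out lower numbers stand for stronger inhibition and higher numbers for weaker inhibition), gives > 100000 nM, which is a limit of the assay.
Compound 2, `Cc1ccc(NC(=O)c2cccc(/C=C3\CC(=O)N(c4ccccc4)C3=O)c2)cc1`, in this assay gives > 100000 nM, again a limit of the assay.
Compound 3, `CCCCCN1C(=O)C/C(=C\c2cccc(C(=O)Nc3ccc(C)cc3)c2)C1=O`, in this assay gives > 100000 nM, also a limit of the assay.

Compound 2 therefore stands at no number at all but at a limit, and its two neighbours share that limit: the limit of > 100000 nM in this assay, at which 3 of the 3 values shown sit. Two measured steps lead into or out of compound 2. The first, a step that the two limits leave unreadable from compound 1 to compound 2, changes the substituent on the amide-type nitrogen outside the ring; the second, a step that the two limits leave unreadable from compound 2 to compound 3, changes the substituent on the amide-type nitrogen in the ring. Neither of them can be read, since both partners sit at the limit.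

The unmeasured compound 4, `O=C(NCc1ccccc1)c1cccc(/C=C2\CC(=O)N(c3ccccc3)C2=O)c1`, differs from compound 2 by benzyl in place of 4-methylphenyl on an amide-type nitrogen. The change sits at the same amide-type nitrogen as the step from compound 1 to compound 2, and that step gave no readable size. Within the data shown here, no step in this assay therefore supports expecting any movement beyond the scatter, in either direction. The expected step from compound 2 to compound 4 in this assay is a step that the limit leaves unreadable from compound 2 to compound 4. Compound 4 is estimated at 150000 nM in this assay, with a range from 40000 nM to 600000 nM, and most likely the assay will again report only a limit.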

Compound 4, half-maximal inhibitory concentration: > 100000 nM
Compound 4 was reported as a limit; the forecaster's own chance of this, stated with the estimate: 85%; the middle value does not contradict the limit.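

In this assay compound 4 gives > 100000 nM, which is a limit of the assay. No new step can be read from compound 1 or compound 2 to compound 4, because all of these compounds share one limit: the limit of > 100000 nM in this assay, at which 4 of the 4 values shown sit.

The compounds shown leave open whether any change at either amide-type nitrogen alters the true value.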